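The source may report more compounds than this note shows. Statements on the series, on what has been measured and on what is new or still open speak of the compounds shown alone.

Compound 1 `c1ccc(Oc2ccc(Cc3nc4ccccc4[nH]3)cc2)cc1` gives 4200 nM in an assay on membranes from brain for binding affinity to Adrenergic receptor alpha-1 (Rattus norvegicus); a higher number here means a weaker inhibitor, a lower number a stronger inhibitor. Compound 2 `CCS(=O)(=O)Nc1ccc2[nH]c(Cc3ccc(Oc4ccccc4)cc3)nc2c1` carries an extra (ethylsulfonyl)amino group and gives 2800 nM in this assay; the step of a 1.5-fold lower number from compound 1 to compound 2 (0.18 log units; within the scatter) is the only one measured, and it stays within the scatter, so compound 2 stands alongside compound 1 rather than apart from it. Compound 3 `CCCS(=O)(=O)Nc1ccc2[nH]c(Cc3ccc(Oc4ccccc4)cc3)nc2c1` differs from compound 2 by methyl in place of hydrogen on a saturated chain carbon, two bonds along the chain from a sulfonyl sulfur. For the measured compounds named here, since the only related step, from compound 1 to compound 2, stayed within the scatter, the expected step of a 1.1-fold lower number from compound 2 to compound 3 (0.05 log units; within the scatter) is none beyond the scatter. For compound 3 in this assay the estimated value is 2500 nM, with a range from 900 nM to 7000 nM.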

Compound 3, half-maximal inhibitory concentration: 4800 nM
For compound 3 the middle estimate is 1.9-fold (0.28 log units) below the measured one; the measured number falls inside the stated range.
By their numbers in this assay, from the lowest: compounds 2, 1 and 3 (each within the scatter of the next).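

Going from ethylsulfonyl to propylsulfonyl gives a 1.7-fold higher number from compound 2 to compound 3 (0.23 log units; within the scatter) in this assay, so a methyl added two bonds along the chain from the sulfonyl sulfur does not measurably move the number. The whole (propylsulfonyl)amino group, in place of hydrogen on an aromatic carbon, gives a 1.1-fold higher number from compound 1 to compound 3 (0.06 log units; within the scatter), so neither sulfonylamino group shown moves the number beyond the scatter. Nothing available here explains these small steps. Still open, going by these compounds, is whether a much longer chain on the sulfonyl, or an amine or a carboxylic acid in its place, would shift the number beyond the scatter.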